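The compounds below may be only part of what the source reports. "The series", "measured", "known", "first", "only" and "open" are said of these compounds alone.

Working notes on the series:
- compound 1 `Oc1c(C(Nc2ccccn2)c2ccccc2F)ccc2cccnc12`: > 10000 nM (a limit)
- compound 2 `Cc1ccc(C)c(C(Nc2ccccn2)c2ccc3cccnc3c2O)c1`: 13800 nM

Going by the values given here, in a functional assay on U-87MG ATCC cells for inhibition, with U-87 MG (Homo sapiens) as the target, read by MTT assay, with a stated time of 72 h (on this read-out higher numbers stand for weaker inhibition and lower numbers for stronger inhibition), compound 2 gives 13800 nM, the only number so far. Compound 1 gives > 10000 nM, which is a limit and not a number.

The next change leads to compound 3 `COc1cccc(C(Nc2ccccn2)c2ccc3cccnc3c2O)c1`: 3-methoxyphenyl in place of 2,5-dimethylphenyl on a saturated chain carbon bound to an aromatic carbon and a nitrogen on an aromatic ring. Among the compounds with values here, the sole measured step at this place is a step that the limit leaves unreadable from compound 1 to compound 2, and it has no readable size because of the limit of > 10000 nM in this assay, at which 1 of the 2 values shown sits. With no measured size or direction to carry over, no step beyond the scatter is expected in this assay. The expected step is a 1.0-fold higher number from compound 2 to compound 3 (0.01 log units; within the scatter). For compound 3 the estimate is 14000 nM, with an expected range of 6000 nM to 35000 nM.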

Compound 3, half-maximal inhibitory concentration: 11900 nM
Beside the measured number, compound 3's estimate is 1.2-fold (0.07 log units) above it; the measured number falls inside the stated range.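

In this assay, this place gives its first readable step: a 1.2-fold lower number from compound 2 to compound 3 (0.06 log units; within the scatter). Swapping 2,5-dimethylphenyl for 3-methoxyphenyl, which brings in one hydrogen-bond acceptor, therefore leaves the two values within the scatter of each other. The steps from compound 1 cannot be read because its value is a limit: the limit of > 10000 nM in this assay, at which 1 of the 3 values shown sits.

Still open, going by these compounds, is whether a group of another kind at this place, such as an aminomethyl or a carboxylic acid in place of the substituted phenyl, would give a step beyond the scatter. On these data alone, the effect of changes elsewhere on the shared core is also open.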